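A few compounds are considered here, and "the series" means these few. Any claim that something is new, unique, unknown or untested is made for them only; others in the source may bear on it.

Compound 1 `COc1cc(NCc2ccccc2)cc(OC)c1OC`: > 80000 nM
Compound 2 `COC(=O)c1cc(CNc2cc(OC)c(OC)c(OC)c2)ccc1OC`: 41100 nM
Compound 3 `C/C=C/C=C/C(=O)N(Cc1ccc(OC)c(O)c1)c1cc(OC)c(OC)c(OC)c1`: 180 nM

Of the compounds shown here, three have so far been tested in a functional assay on KYSE-450 cells (Homo sapiens) for inhibition, read by MTT assay, with a stated time of 48 h; on this read-out higher numbers stand for weaker inhibition and lower numbers for stronger inhibition. Compound 1 gives > 80000 nM, which is a limit of the assay and not a number. Compound 2 gives 41100 nM. Compound 3 gives 180 nM, the lowest of the two numbers shown; the nearest number, that of compound 2, lies far higher, well beyond the usual scatter.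

Compound 4 `COc1ccc(CN(C(=O)C(C)C)c2cc(OC)c(OC)c(OC)c2)cc1O` has not yet been measured in this assay. It differs from compound 3 in one place: isopropyl in place of penta-1,3-dien-1-yl on a carbonyl carbon. The change sits on the carbonyl carbon whose other neighbour is the amide-type nitrogen. For the measured compounds named here, no measured pair here shows what this exchange does, so the expectation must rest on compound 3 alone. A move toward weaker inhibition, by more than the scatter, is expected, since only compound 3, with its 180 nM, reaches strong inhibition among the compounds shown. Compound 4 is expected to give 2000 nM, within a range of 400 nM to 15000 nM. The estimated step of an 11-fold higher number from compound 3 to compound 4 (1.05 log units; beyond the scatter) is toward a higher number.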

Compound 4, half-maximal inhibitory concentration: 390 nM
Compound 4: middle estimate off by 5.1-fold (0.71 log units), on the high side; the whole stated range lies above it.
By their numbers in this assay, from the lowest: compound 3; then compound 4; then compound 2. At a limit, above all of these: compound 1.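

In this assay, putting isopropyl in place of penta-1,3-dien-1-yl on the carbonyl carbon gives a 2.2-fold higher number from compound 3 to compound 4 (0.34 log units; beyond the scatter), a modest step for a change that removes both double bonds of the chain and two of its carbons. Strong inhibition in this pair therefore does not depend on the penta-1,3-dien-1-yl group, since compound 4 still reaches 390 nM with the smaller, branched isopropyl. This is a single exchange at a single position, and nothing measured here explains the size of the step.

Still open, going by these compounds, is what a methyl group, a longer chain such as hexyl, or a phenyl ring would do on this carbonyl carbon. Also open, on these data alone, is how a chain ending in an amine or a carboxylic acid would behave there.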